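The source may report more compounds than this note shows. Statements on the series, on what has been measured and on what is new or still open speak of the compounds shown alone.

Compound 1 `CCc1ccccc1-n1nncc1CN1C(=O)C2(C(C#N)=C(N)Oc3c(N)cc4nc5ccccc5nc4c32)c2ccccc21` gives 24600 nM in a functional assay on MCF7 cells (Homo sapiens) for antiproliferative activity, read by MTT assay, with a stated time of 48 h; a higher number here means a weaker inhibitor, a lower number a stronger inhibitor.
Compound 2 `CCc1cccc(C)c1-n1nncc1CN1C(=O)C2(C(C#N)=C(N)Oc3c(N)cc4nc5ccccc5nc4c32)c2ccccc21` gives > 50000 nM in this assay, a limit of the assay.
Compound 3 `N#CC1=C(N)Oc2c(N)cc3nc4ccccc4nc3c2C12C(=O)N(Cc1cnnn1-c1ccc(Cl)cc1Cl)c1ccccc12` gives > 50000 nM in this assay, likewise only a limit.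

Compound 3 thus stands at the limit rather than at a number, where (the limit of > 50000 nM in this assay, at which 2 of the 3 values shown sit). Compound 4 `Cc1ccc(Cl)cc1-n1nncc1CN1C(=O)C2(C(C#N)=C(N)Oc3c(N)cc4nc5ccccc5nc4c32)c2ccccc21` changes the group on the triazole nitrogen: 5-chloro-2-methylphenyl in place of 2,4-dichlorophenyl on an aromatic nitrogen. Going by the values given here, two measured steps bear on this position. The step of an at least 2.0-fold higher number from compound 1 to compound 3 (0.30 log units; that floor lies within the scatter) weakened inhibition, while the step that the two limits leave unreadable from compound 2 to compound 3. Both steps thus point toward compound 3 being a weak inhibitor, and compound 4 keeps a chlorine while regaining an alkyl group like compound 1. Compound 4 is therefore expected to sit near the limit again, with an at least 1.1-fold lower number from compound 3 to compound 4 (0.04 log units; that floor lies within the scatter) as the estimated step. For compound 4 the estimate in this assay is 45000 nM, ranging from 15000 nM to 150000 nM.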

Compound 4, half-maximal inhibitory concentration: 43500 nM
Compound 4: the middle estimate sits 1.0-fold (0.01 log units) above what was measured; measured number inside the range.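

With 5-chloro-2-methylphenyl on the aromatic nitrogen, compound 4 gives a real number in this assay, whereas the 2,4-dichlorophenyl and 2-ethyl-6-methylphenyl groups reach only a limit: the limit of > 50000 nM in this assay, at which 2 of the 4 values shown sit. Against those two limits the change reads only as a floor, namely an at least 1.1-fold lower number from compound 3 to compound 4 (0.06 log units; that floor lies within the scatter) and an at least 1.1-fold lower number from compound 2 to compound 4 (0.06 log units; that floor lies within the scatter). Against the 2-ethylphenyl group it gives a 1.8-fold higher number from compound 1 to compound 4 (0.25 log units; within the scatter), so compound 4 and compound 1 cannot be told apart here.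

All the groups shown are phenyl rings bearing chlorine or alkyl groups. Going by these compounds, how an amine, a carboxylic acid or a longer chain on that phenyl ring would read in this assay stays open.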